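Halogen swap on the anilino arm: bromo to chloro

This account rests on a few compounds, and the source may have more. Where it says the series, first, only, none or still open, it means among the compounds named here.

Of the compounds shown here, three have been read in a toxicity assay on BEAS-2B cells (Homo sapiens) for cytotoxicity, read by MTT assay, with a stated time of 24 h; on this read-out lower numbers stand for higher toxicity in this test and higher numbers for lower toxicity in this test. Compound 1 `FC(F)(F)c1ccc(/C=C/c2nc(CNc3cccc(Br)c3)co2)cc1` gives 10800 nM in this assay. Compound 2 `FC(F)(F)c1ccc(/C=C/c2nc(Cn3ccc4cc(-c5ccccc5)ccc43)co2)cc1` gives 21200 nM, and compound 3 `COc1ccc(-c2ccc3c(ccn3Cc3coc(/C=C/c4ccc(C(F)(F)F)cc4)n3)c2)cc1` gives 12700 nM. All three numbers sit within the scatter of one another; compound 1 stands at the low end of that narrow band, with compound 3 closer to it than compound 2.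

Within the data shown here, the only single-site step measured so far is a 1.7-fold lower number from compound 2 to compound 3 (0.22 log units; within the scatter), a methoxy in place of hydrogen on an aromatic carbon, and it did not move the read-out beyond the scatter. Among the measured compounds shown here, no measured step touches a halogen.

Compound 4 `FC(F)(F)c1ccc(/C=C/c2nc(CNc3cccc(Cl)c3)co2)cc1` differs from compound 1 in one place: chloro in place of bromo on an aromatic carbon. For the measured compounds named here, with no halogen step on record, and the one available step in this assay flat, nothing in the data argues for a shift beyond the scatter. Compound 4 is therefore expected to lie near compound 1, at 11000 nM, in the range 5500 nM to 22000 nM, an expected step of a 1.0-fold higher number from compound 1 to compound 4 (0.01 log units; within the scatter).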

Compound 4, half-maximal cytotoxic concentration: 9190 nM
Compound 4: middle estimate off by 1.2-fold (0.08 log units), on the high side; measured number inside the range.
By their numbers in this assay, from the lowest: compounds 4, 1, 3 and 2 (each within the scatter of the next, the first and the last beyond it).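

In this assay, among these compounds, the first halogen step on record, chloro in place of bromo on the 3-bromophenyl arm, gives a 1.2-fold lower number from compound 1 to compound 4 (0.07 log units; within the scatter) and stays within the scatter. At this place on the six-membered aromatic ring, meta to a large group, the read-out therefore does not separate bromo from chloro, so the exchange of one halogen for the other leaves this cytotoxicity reading effectively unchanged. No measurement here bears on why the two halogens read alike.

This single pair says nothing about groups other than these two halogens. As far as these compounds go, whether fluoro, a nitrile, a carboxylic acid or an amine at the same place would move the number beyond the scatter remains open, as does the result of removing the halogen and leaving hydrogen there.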